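This account rests on a few compounds, and the source may have more. Where it says the series, first, only, none or still open, it means among the compounds named here.

Measured in an ADME assay on MRC5 cells (Homo sapiens) for inhibition, with a stated time of 72 h; a higher number here means that more compound is needed for the effect, a lower number that less compound is needed:
- compound 1 `CO[C@H]1CC[C@H](NC(=O)c2n[nH]cc2NC(=O)c2ccccc2)CC1`: 800 nM
- compound 2 `CO[C@H]1CC[C@H](NC(=O)c2n[nH]cc2NC(=O)c2ccc(N3CCCC3)cc2)CC1`: > 50000 nM

Compound 2 stands at the limit of > 50000 nM in this assay, at which 1 of the 2 values shown sits. Its > 50000 nM is a limit of the assay and not a number.

Compound 3 `CO[C@H]1CC[C@H](NC(=O)c2n[nH]cc2NC(=O)c2ccc(N3CCN(C)CC3)cc2)CC1` differs from compound 2 in one place, with 4-methylpiperazin-1-yl in place of pyrrolidin-1-yl on an aromatic carbon. For the measured compounds named here, only one measured step bears on this change. That step, an at least 62-fold higher number from compound 1 to compound 2 (1.79 log units; beyond the scatter), is large and beyond the scatter, and it put pyrrolidin-1-yl in place of hydrogen at the same carbon. Compound 3 also carries a ring at that carbon, so with an at least 62-fold higher number from compound 1 to compound 2 (1.79 log units; beyond the scatter) as the guide it is expected to remain much closer to compound 2 than to compound 1 in this assay. Going by the values given here, no measured step exchanges one such ring for another, so the size of the change remains uncertain. A small step towards a lower number is expected, and it may not exceed the scatter. The expected change is an at least 1.6-fold lower number from compound 2 to compound 3 (0.22 log units; that floor lies within the scatter). For compound 3 the estimate is 30000 nM, with an expected range from 8000 nM to 50000 nM.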

Compound 3, half-maximal effective concentration: 20000 nM
Compound 3: the middle estimate sits 1.5-fold (0.18 log units) above what was measured; measured number inside the range.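

In this assay, for the compounds shown here, the two rings at this aromatic carbon, para to a large group, are not equivalent: 4-methylpiperazin-1-yl in place of pyrrolidin-1-yl gives an at least 2.5-fold lower number from compound 2 to compound 3 (0.39 log units; beyond the scatter), the first measured exchange of one ring for another here, and it lies beyond the scatter. The higher number seen with pyrrolidin-1-yl also recurs with a second ring, as 4-methylpiperazin-1-yl in place of hydrogen gives a 25-fold higher number from compound 1 to compound 3 (1.40 log units; beyond the scatter), which is likewise beyond the scatter. The exchange between the two rings can be read only as a floor, as the value of compound 2 is a limit of the assay and not a number: the limit of > 50000 nM in this assay, at which 1 of the 3 values shown sits.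

From the compounds shown here alone, the true distance between compound 2 and compound 3 stays open, as does whether the ring size, the second ring nitrogen or its methyl separates them, since the exchange alters all three at once. The compounds shown also do not tell whether a smaller group at this carbon, such as methoxy, or an open-chain amine such as dimethylamino, would raise the number as well, or by how much.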